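Swapping the ring on the carbonyl of a weakly cytotoxic chalcone

This account rests on a few compounds, and the source may have more. Where it says the series, first, only, none or still open, it means among the compounds named here.

Among the compounds with values here, compound 1 `COc1cc(-c2cc(/C=C/C(=O)c3ccc(N)cc3)[nH]n2)cc(OC)c1OC` is tested in a functional assay on UACC-257 cells (Homo sapiens) for cytotoxicity, read by sulforhodamine B assay, with a stated time of 48 h, tested at 1 uM (a higher number here means a weaker effect of the compound at the concentration tested, a lower number a stronger effect), where compound 1 gives 91%, the higher of the two numbers so far. Compound 2 `COc1ccc(-c2cc(/C=C/C(=O)c3ccc(OC)c(OC)c3)[nH]n2)cc1` gives 87% in this assay, and the two values lie within the usual scatter of each other. Compound 3 `COc1ccc(C(=O)/C=C/c2cc(-c3cc(OC)c(OC)c(OC)c3)n[nH]2)cc1OC` has not been measured; it differs from compound 1 by 3,4-dimethoxyphenyl in place of 4-aminophenyl on a carbonyl carbon. Within the data shown here, with no comparable step among the measured compounds, the step of a number 5 percentage points lower from compound 1 to compound 3 (within the scatter) is expected to stay within the scatter, with no clear direction. Compound 3 is therefore expected to give about 86%, likely between 70% and 98%.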

Compound 3, a percentage reported as activity, at one concentration (the size of the read-out at that concentration, not a potency): 81%
Compound 3: middle estimate off by 5 percentage points, on the high side; low and high end bracket the measured number.
By their numbers in this assay, from the lowest: compounds 3, 2 and 1 (each within the scatter of the next).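

In this assay, 3,4-dimethoxyphenyl in place of 4-aminophenyl on the carbonyl carbon gives a number 10 percentage points lower from compound 1 to compound 3 (within the scatter). Within the data shown here, this is the first step that can be read at this position, and it shows that a larger group without the hydrogen-bond donor of 4-aminophenyl leaves the read-out within the scatter. Nothing available explains this result. From the compounds shown here alone, whether a plain methyl group or a benzoic acid at this place would give a step beyond the scatter remains open. A single step also cannot show whether this swap behaves the same way on another core.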